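Phenyl in Place of Pyridinyl on the Pyrazole Core

The source may report more compounds than this note shows. Statements on the series, on what has been measured and on what is new or still open speak of the compounds shown alone.

Compound 1 `COc1ccc(-c2c(C)nn(-c3nc(-c4ccc(Cl)c(Cl)c4)c(SC(C)C)s3)c2C(=O)O)cc1` gives 2100 nM in a functional assay on BJAB cells (Homo sapiens) for antiproliferative activity, with a stated time of 4 days; a higher number here means that more compound is needed for the effect, a lower number that less compound is needed.
Compound 2 `COc1ccccc1-c1c(C)nn(-c2nc(-c3ccc(Cl)c(Cl)c3)c(SC(C)C)s2)c1C(=O)O` gives 14700 nM in this assay.
Compound 3 `Cc1nn(-c2nc(-c3ccc(Cl)c(Cl)c3)c(SC(C)C)s2)c(C(=O)O)c1-c1cccnc1` gives 12000 nM in this assay.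

Compound 3 stands second highest of the three numbers: its nearest neighbour is compound 2, a difference within the scatter, and its furthest is compound 1, a 5.7-fold higher number from compound 1 to compound 3 (0.76 log units; beyond the scatter). The step to compound 4 `Cc1nn(-c2nc(-c3ccc(Cl)c(Cl)c3)c(SC(C)C)s2)c(C(=O)O)c1-c1ccccc1` is phenyl in place of pyridin-3-yl on an aromatic carbon.

For the measured compounds named here, two measured steps bear on it. From compound 1 the shift to compound 2 gave a 7.0-fold higher number from compound 1 to compound 2 (0.85 log units; beyond the scatter), and the shift to compound 3 gave a 5.7-fold higher number from compound 1 to compound 3 (0.76 log units; beyond the scatter), while a 1.2-fold lower number from compound 2 to compound 3 (0.09 log units; within the scatter) stayed within the scatter. None of these removes the ring nitrogen alone, so the step to compound 4 is only loosely anchored; the two higher numbers of compound 2 and compound 3 suggest the new ring could land near them, with a possible shift toward compound 1.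

Compound 4 is therefore expected to show a 2.0-fold lower number from compound 3 to compound 4 (0.30 log units; within the scatter), with an estimated value of 6000 nM and a range from 2000 nM to 18000 nM.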

Compound 4, half-maximal effective concentration: 3000 nM
Beside the measured number, compound 4's estimate is 2.0-fold (0.30 log units) above it; the range from low to high includes it.
By their numbers in this assay, from the lowest: compounds 1 and 4 (each within the scatter of the next); then compounds 3 and 2 (each within the scatter of the next).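

In this assay, for the compounds shown here, replacing pyridin-3-yl with phenyl changes only one ring atom, nitrogen to carbon, and that single change gives a 4.0-fold lower number from compound 3 to compound 4 (0.60 log units; beyond the scatter), so the ring nitrogen alone separates these two compounds by more than the scatter. The new compound also shows that the effect of a methoxy group on this ring depends on where it sits: removing it from 2-methoxyphenyl gives a 4.9-fold lower number from compound 2 to compound 4 (0.69 log units; beyond the scatter), while removing it from 4-methoxyphenyl gives a 1.4-fold higher number from compound 1 to compound 4 (0.15 log units; within the scatter), a change within the scatter. Nothing available explains these differences.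

From the compounds shown here alone, whether a 4-aminophenyl or 4-chlorophenyl ring would stay within the scatter of compound 4 remains open. So does whether pyridin-4-yl, with its ring nitrogen elsewhere, would behave like compound 3.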